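Removing the chloro group from the core of compound 3

The source may hold more compounds than are shown below. What is called first, only, known or untested is meant among the compounds shown, and "the series" means these compounds.

Measured so far in a functional assay on MCF7 cells (Homo sapiens) for cytotoxicity, read by sulforhodamine B assay, with a stated time of 48 h; on this read-out higher numbers stand for weaker inhibition of growth and lower numbers for stronger inhibition of growth:
compound 1 `CCN(CC)CN1C(=O)/C(=N\c2nc3ccc(C)cc3s2)c2c(Br)cccc21` gives 30200 nM
compound 2 `Cc1ccc2nc(/N=C3\C(=O)N(CN4CCCCC4)c4ccccc43)sc2c1` gives 37800 nM
compound 3 `O=C1C(=O)N(CN(c2ccccc2)c2ccccc2)c2cccc(Cl)c21` gives 29700 nM

The three values sit close together, and the value of compound 3 lies within the scatter of both compound 1 and compound 2, so no order among them can be read from these numbers. Compound 4 `O=C1C(=O)N(CN(c2ccccc2)c2ccccc2)c2ccccc21` differs from compound 3 in a single place: hydrogen in place of chloro on an aromatic carbon. Within the data shown here, no pair of measured compounds shows a step of this kind, so there is nothing to calibrate it against. Given that all three measured numbers fall in the same narrow band, the step from compound 3 to compound 4 is expected to stay within the scatter, as a 1.2-fold higher number from compound 3 to compound 4 (0.07 log units; within the scatter). Compound 4 is therefore estimated at 35000 nM, with a likely range from 15000 nM to 80000 nM.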

Compound 4, concentration for 50% growth inhibition: 23700 nM
Estimate against measurement, compound 4: 1.5-fold (0.17 log units) above; measured number inside the range.
By their numbers in this assay, from the lowest: compounds 4, 3, 1 and 2 (each within the scatter of the next).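

In this assay hydrogen in place of chloro on this aromatic carbon gives a 1.3-fold lower number from compound 3 to compound 4 (0.10 log units; within the scatter) and is the only single-place step shown. The chloro group is therefore not needed at this position to keep growth inhibition at the level of compound 3. No available measurement bears on the reason for this. As far as these compounds go, whether an amine, a methoxy group or a carboxylic acid on this aromatic carbon would stay in the same narrow band remains open.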